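A few compounds are considered here, and "the series" means these few. Any claim that something is new, unique, unknown or untested is made for them only; others in the source may bear on it.

Measured so far in an ADME assay on BCBL1 cells (Homo sapiens) for cytotoxicity, with a stated time of 7 days (a higher number here means that more compound is tolerated, a lower number that less compound is tolerated), each value a limit of the assay:

- Compound 1 `CCCCCCCCOc1nc(N)nc2c1ncn2/C=C1/CC1(CO)CO` gives > 20000 nM as a limit
- Compound 2 `CC(C)Nc1nc(N)nc2c1ncn2/C=C1/CC1(CO)CO` gives > 20000 nM as a limit
- Compound 3 `CCCCCCSc1nc(N)nc2c1ncn2/C=C1/CC1(CO)CO` gives > 20000 nM as a limit

Compound 3 therefore has no exact number in this assay, only its limit of > 20000 nM as a starting point. The next structure, compound 4 `CCCOc1nc(N)nc2c1ncn2/C=C1/CC1(CO)CO`, carries propoxy in place of hexylsulfanyl on an aromatic carbon as its one difference.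

The closest guides are a step that the two limits leave unreadable from compound 1 to compound 3 and a step that the two limits leave unreadable from compound 2 to compound 3, and a step that the two limits leave unreadable from compound 1 to compound 2 adds a third. None of these has a readable size. The whole set comes down to the limit of > 20000 nM in this assay, at which 3 of the 3 values shown sit, and offers no measured trend in either direction. Compound 1, which also has an oxygen-linked chain in octyloxy, gives > 20000 nM as a limit.

No step beyond the usual scatter is expected, and the estimated change is a step that the limit leaves unreadable from compound 3 to compound 4 with no firm direction. For compound 4 the estimated value is 25000 nM, with an expected range from 12000 nM to 50000 nM as the estimate.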

Compound 4, half-maximal cytotoxic concentration: > 20000 nM
Compound 4: only a limit was reported (the forecaster's own chance of this, stated with the estimate: 85%); the middle value does not contradict the limit.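

Compound 4 joins compound 1, compound 2 and compound 3 in reporting only a limit, so no step among these compounds can be read in this assay: the limit of > 20000 nM in this assay, at which 4 of the 4 values shown sit.

The compounds shown leave open the concentration at which any of them would harm the cells, and whether their different side chains change it.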